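The source may hold more compounds than are shown below. What is called first, only, known or untested is meant among the compounds shown, and "the series" means these compounds.

Of the compounds shown here, three sharing one core have been tested in a functional assay on A549 cells (Homo sapiens) for inhibition, read by CCK-8 assay, with a stated time of 48 h; on this read-out lower numbers stand for stronger inhibition and higher numbers for weaker inhibition. Compound 1 `COc1cc(-c2ccnc3cc(-c4ccc(C)c(C)c4)nn23)cc(OC)c1OC`, which carries 3,4-dimethylphenyl, gives 272 nM. Compound 2 `COc1cc(-c2ccnc3cc(-c4cccc(C#N)c4)nn23)cc(OC)c1OC`, which carries 3-cyanophenyl, gives > 10000 nM, and this is a limit of the assay, not a number. Compound 3 `COc1cc(-c2ccnc3cc(-c4ccc(C(F)(F)F)cc4)nn23)cc(OC)c1OC`, which carries 4-(trifluoromethyl)phenyl, gives 2070 nM, the higher of the two actual numbers. Its nearest neighbour is compound 1, and the gap is a 7.6-fold higher number from compound 1 to compound 3 (0.88 log units; beyond the scatter). Against the limit, the data show an at least 4.8-fold lower number from compound 2 to compound 3 (0.68 log units; beyond the scatter).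

Compound 4 `COc1cc(-c2ccnc3cc(-c4cccc(C)c4)nn23)cc(OC)c1OC` is still unmeasured. It departs from compound 3 by 3-methylphenyl in place of 4-(trifluoromethyl)phenyl on an aromatic carbon. The closest guide is the 3,4-dimethylphenyl of compound 1, since the measured 7.6-fold higher number from compound 1 to compound 3 (0.88 log units; beyond the scatter) shows what leaving that group for 4-(trifluoromethyl)phenyl costs. The larger at least 36-fold higher number from compound 1 to compound 2 (1.56 log units; beyond the scatter) shows that a change at this place can also move the number far. A lower number is therefore expected in this assay, somewhat short of the full gap to compound 1. The expected change is a 3.8-fold lower number from compound 3 to compound 4 (0.58 log units; beyond the scatter). Compound 4 is estimated at 550 nM, with an expected range from 180 nM to 2500 nM.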

Compound 4, half-maximal inhibitory concentration: 5730 nM
Compound 4: the middle estimate sits 10-fold (1.02 log units) below what was measured; measured number above the stated range.
By their numbers in this assay, from the lowest: compound 1; then compound 3; then compound 4. At a limit, above all of these: compound 2.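

In this assay, hydrogen in place of methyl on an aromatic carbon, which turns the 3,4-dimethylphenyl of compound 1 into the 3-methylphenyl of compound 4, gives a large step: a 21-fold higher number from compound 1 to compound 4 (1.32 log units; beyond the scatter). One methyl on the phenyl group is therefore not enough to keep the number low, and 3-methylphenyl even falls behind 4-(trifluoromethyl)phenyl, with a 2.8-fold higher number from compound 3 to compound 4 (0.44 log units; beyond the scatter). The value of compound 2, > 10000 nM, is a limit of the assay. Against that limit, methyl in place of cyano gives an at least 1.7-fold lower number from compound 2 to compound 4 (0.24 log units; that floor lies within the scatter).

The compounds shown leave open whether a chlorine, a methoxy group or an amine could stand in for the lost methyl and restore a number near that of compound 1, 272 nM. For the compounds shown here, they also leave open whether that methyl would act alone, without the one kept in compound 4.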